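The source may hold more compounds than are shown below. What is called first, only, known or untested is meant among the compounds shown, and "the series" means these compounds.

Measured so far:
- Compound 1 `O=C(CSc1nc(Nc2ccccc2)c2ccccc2n1)Nc1ccc(Cl)cc1Cl` gives 8410 nM in a functional assay on NCI-H1975 cells (Homo sapiens) for inhibition, read by MTT assay, with a stated time of 72 h; on this read-out lower numbers stand for stronger inhibition and higher numbers for weaker inhibition.
- Compound 2 `C=CC(=O)Nc1cccc(NC(=O)CSc2nc(Nc3ccccc3Cl)c3ccccc3n2)c1` gives 10000 nM in this assay.

Among the compounds with values here, only two compounds carry numbers. Compound 1 and compound 2 lie within the usual scatter of each other, so the two readings cannot be told apart, and neither compound can be called the stronger or the weaker of the pair on this evidence. Both numbers sit at the weak end of what this assay resolves.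

Compound 3 `C=CC(=O)Nc1cccc(NC(=O)CSc2nc(Nc3ccc(F)c(Cl)c3)c3ccccc3n2)c1` has not yet been measured. It differs from compound 2 in one place: 3-chloro-4-fluorophenyl in place of 2-chlorophenyl on a nitrogen on an aromatic ring. The rest of the shared core, including the acrylamide-bearing side and the thioether linker, is unchanged.

Within the data shown here, there is no measured pair that shows what a change on this nitrogen does, so no direction can be read from the data. Compound 3 is therefore expected to stay close to compound 2, with a step of a 1.3-fold lower number from compound 2 to compound 3 (0.10 log units; within the scatter), which would be none beyond the scatter. The estimate for compound 3 is 8000 nM, with a range from 2500 nM to 25000 nM.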

Compound 3, half-maximal inhibitory concentration: > 50000 nM
Compound 3 was reported as a limit; the forecaster's own chance of this, stated with the estimate: 25%; middle value at least 6.2-fold (0.79 log units) from the limit.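

The nitrogen's substituent is not a silent position: in this assay, 3-chloro-4-fluorophenyl in place of 2-chlorophenyl gives an at least 5.0-fold higher number from compound 2 to compound 3 (0.69 log units; beyond the scatter). Within the data shown here, this is the first measured step at this position, and because it lies beyond the scatter, it shows that changing this ring can weaken inhibition on this read-out, something the two earlier compounds could not show. The reading of compound 3 is a limit and not a number: the limit of > 50000 nM in this assay, at which 1 of the 3 values shown sits.

The step changes two things at once, since the ring gains a fluorine and its chlorine also sits at a different numbered position, so the compounds shown leave open which of these matters; 3-chlorophenyl or 4-fluorophenyl on this nitrogen would separate the two. Also open, on these data alone, is how a ring carrying a methoxy group or an amine would read here, and whether any group at this position can bring the number in this assay well below that of compound 2.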